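The compounds below may be only part of what the source reports. "The series", "measured", "known", "first", "only" and "open" are said of these compounds alone.

Measured compounds:
compound 1, `O=C(O)c1ccc(Nc2ncnc3sc(Nc4c(Cl)cccc4Cl)nc23)cc1`; compound 2, `FC(F)(F)c1ccc(Nc2nc(N3CCC3)nc3sc(Nc4c(Cl)cccc4Cl)nc23)cc1`.

In a functional assay on HEK293 cells for antagonist activity at transient receptor potential cation channel subfamily V member 1 (Rattus norvegicus), read by calcium flux (on this read-out lower numbers stand for stronger inhibition and higher numbers for weaker inhibition), compound 1 gives > 5000 nM. For compound 1 this value is a limit of the assay and not a number; (the limit of > 5000 nM in this assay, at which 1 of the 2 values shown sits). In this assay compound 2 gives 25 nM. Among the values shown, compound 2 therefore stands as the only one reported as a number, the other being a limit.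

Compound 3, `CN(C)c1nc(Nc2ccc(C(F)(F)F)cc2)c2nc(Nc3c(Cl)cccc3Cl)sc2n1`, has not yet been measured. Compared with compound 2, the change is dimethylamino in place of azetidin-1-yl on an aromatic carbon. No step between two measured compounds is shown here, so there is no measured change to lean on for this swap; the two groups are both small, uncharged, carry no hydrogen-bond donor and one acceptor each, and sit at the same position of the shared core. In this assay compound 3 is expected to land close to compound 2, with any difference most likely within the usual scatter, and at most a modest weakening. The expected step from compound 2 to compound 3 is a 1.4-fold higher number from compound 2 to compound 3 (0.15 log units; within the scatter). The estimate for compound 3 is 35 nM, with a range from 12 nM to 110 nM.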

Compound 3, half-maximal inhibitory concentration: 43 nM
Compound 3: the middle estimate sits 1.2-fold (0.09 log units) below what was measured; the measured number falls inside the stated range.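

Replacing azetidin-1-yl with dimethylamino, on the aromatic carbon between two ring nitrogen atoms, gives a 1.7-fold higher number from compound 2 to compound 3 (0.24 log units; within the scatter) in this assay. Among the compounds shown here, this is the first measured comparison at this position, and it shows that the four-membered ring of compound 2 is not required for activity in this read-out: compound 3, which has no ring in this group, cannot be told apart from compound 2 here. The data shown give no reason why these two groups read alike, and this single pair cannot show that the position tolerates other changes.

Going by these compounds, both groups are small and joined to the shared core through nitrogen, so it remains open how a larger piperidin-1-yl or morpholin-4-yl group, or a plain amino group carrying its own hydrogens, would behave at this carbon. On these data alone, compound 1 differs from compound 2 in more than one place, so it cannot settle what this position alone contributes, and the effect of having only a hydrogen on this carbon also remains open.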